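A few compounds are considered here, and "the series" means these few. Any claim that something is new, unique, unknown or untested is made for them only; others in the source may bear on it.

Working notes on the series.

In a functional assay on DU-145 cells (Homo sapiens) for inhibition, read by trypan blue exclusion, with a stated time of 96 h (on this read-out higher numbers stand for weaker inhibition of growth and lower numbers for stronger inhibition of growth), compound 2 `Cc1ccc(CS/C(=C/c2c[nH]c3ccc(Cl)cc23)C(=O)c2ccc(Cl)cc2)cc1` gives 1000 nM. On the numbers at hand compound 2 is level with compound 1 `COc1cc(OC)c(/C=C(/SCc2ccc(Cl)cc2)C(=O)c2ccc(Br)cc2)c(OC)c1`, which in this assay gives 1000 nM; the two are within the scatter of each other and together they hold the lowest numbers of the three measured. The furthest measured compound is compound 3 `Cc1ccsc1/C=C(\C(=O)c1ccc(Cl)cc1)S(=O)(=O)Cc1ccc(Cl)cc1`, which in this assay gives 25000 nM, a higher number than compound 2 by a step beyond the scatter. Compound 3 differs from compound 2 in more than one place, so only the two values themselves are compared here; no single change can be read from that pair.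

The unmeasured compound 4 `Cc1ccc(CS/C(=C/c2cccc(Cl)c2Cl)C(=O)c2ccc(Cl)cc2)cc1` differs from compound 2 in one place: 2,3-dichlorophenyl in place of 5-chloro-1H-indol-3-yl on a double-bonded chain carbon bound to a double-bonded chain carbon. Going by the values given here, no step between measured compounds isolates this kind of change. Compound 1 and compound 2, which carry different groups on the same double-bonded chain carbon, sit level with each other, so an exchange of the aromatic group at that position gives no ground for expecting a large step in either direction.

The expectation is therefore a step from compound 2 to compound 4 of a 1.5-fold higher number from compound 2 to compound 4 (0.18 log units; within the scatter), within or close to the scatter. Compound 4 is estimated at 1500 nM in this assay, with a range from 500 nM to 5000 nM.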

Compound 4, concentration for 50% growth inhibition: 25000 nM
For compound 4 the middle estimate is 17-fold (1.22 log units) below the measured one; measured number above the stated range.
By their numbers in this assay, from the lowest: compounds 1 and 2 (each within the scatter of the next); then compounds 3 and 4 (each within the scatter of the next).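

In this assay, going by these compounds alone, the step of a 25-fold higher number from compound 2 to compound 4 (1.40 log units; beyond the scatter) is the first to isolate a single change, and it shows that the group at this position can by itself move the number beyond the scatter. The change replaces 5-chloro-1H-indol-3-yl, with its five-membered aromatic ring and 1 hydrogen-bond donor, by 2,3-dichlorophenyl, with 0 hydrogen-bond donors and a second chlorine, so several features differ at once and this one pair cannot separate them. Nothing on hand bears on why the number rises with this exchange.

The compounds shown leave open which of these differences carries the step, and whether it belongs to the loss of 5-chloro-1H-indol-3-yl or to the arrival of 2,3-dichlorophenyl. An unsubstituted phenyl, a pyridyl or an aminophenyl on the same double-bonded chain carbon, with the rest of compound 2 kept, would show whether the number stays with that of compound 2 or with that of compound 4.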